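Swapping Fluoro for Cyano on Compound 1

This account rests on a few compounds, and the source may have more. Where it says the series, first, only, none or still open, it means among the compounds named here.

Measured in a functional assay on KG-1 cells (Homo sapiens) for cytotoxicity, read by luminescence and CellTiter-Glo, with a stated time of 3 days (a lower number here means a stronger inhibitor, a higher number a weaker inhibitor), so far:
compound 1 (`N#Cc1ccc(NC(=O)c2ccc3cccnc3c2O)c(F)c1`) gives 3260 nM
compound 2 (`O=C(Nc1ccc(C(F)(F)F)cc1)c1cc(Br)ccc1O`) gives 610 nM

For the measured compounds named here, only these two compounds have numbers so far. Compound 1 holds the higher number of the pair, so it is the weaker inhibitor, and the gap to compound 2 lies beyond the usual scatter of repeated measurements.

Compound 3 (`N#Cc1ccc(NC(=O)c2ccc3cccnc3c2O)c(C#N)c1`) keeps the core of compound 1 but carries cyano in place of fluoro on an aromatic carbon, ortho to a large group and meta to a cyano group (cyano in place of fluoro on an aromatic carbon). Going by the values given here, no two measured compounds differ in just one place, so the data do not show what such a swap does in this assay. With nothing to point either way, the expected step (a 1.1-fold lower number from compound 1 to compound 3 (0.04 log units; within the scatter)) is none beyond the scatter. The estimated value for compound 3 is 3000 nM (expected range 1000 nM to 10000 nM).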

Compound 3, half-maximal inhibitory concentration: 3770 nM
Beside the measured number, compound 3's estimate is 1.3-fold (0.10 log units) below it; the measured number falls inside the stated range.
By their numbers in this assay, from the lowest: compound 2; then compounds 1 and 3 (each within the scatter of the next).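

In this assay, for the compounds shown here, the swap of fluoro for cyano on this aromatic carbon, ortho to a large group and meta to a cyano group, gives the first step between compounds that differ in one place (a 1.2-fold higher number from compound 1 to compound 3 (0.06 log units; within the scatter)). Going from 1 heavy atom to 2 heavy atoms, and adding 1 hydrogen-bond acceptor, therefore leaves compound 1 and compound 3 indistinguishable in this measurement. No available measurement offers a reason for this result.

Going by these compounds, it remains open whether a different kind of group at this position, such as an amine, a carboxylic acid or a longer chain, would move the number beyond the scatter. On these data alone, the same swap on another part of the shared core also remains untested by these compounds.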